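This account rests on a few compounds, and the source may have more. Where it says the series, first, only, none or still open, it means among the compounds named here.

In an assay on HBE cells for positive allosteric modulation of Cystic fibrosis transmembrane conductance regulator variant F508del (Homo sapiens) (on this read-out higher numbers stand for an effect only at larger amounts of compound and lower numbers for an effect already at smaller amounts), compound 1 `COc1ccc(C(C)C)cc1CN[C@H]1[C@H](C(C)(C)C)[C@@H](C(=O)O)N(C(=O)C2CCCCC2)[C@H]1c1ccccc1` gives 188 nM, and compound 2 `COc1ccc(C(C)(C)C)cc1CN[C@H]1[C@H](C(C)(C)C)[C@@H](C(=O)O)N(C(=O)C2CCCCC2)[C@H]1c1ccccc1` gives 113 nM. Among the measured compounds shown here, the single step between them, methyl in place of hydrogen on a saturated chain carbon bound to an aromatic carbon and two saturated chain carbons, gave a 1.7-fold lower number from compound 1 to compound 2 (0.22 log units; within the scatter). Compound 2 thus holds the lowest of the two numbers, but its distance to compound 1 lies within the scatter, so no order can be read from them.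

Compound 3 `COc1ccc(C23CC4CC42C3)cc1CN[C@H]1[C@H](C(C)(C)C)[C@@H](C(=O)O)N(C(=O)C2CCCCC2)[C@H]1c1ccccc1` differs from compound 2 in one place: a group of 6 heavy atoms (6 carbon; 2 three-membered non-aromatic rings of carbon only, one four-membered non-aromatic ring of carbon only) in place of a group of 4 heavy atoms (4 carbon; no ring), on an aromatic carbon. For the measured compounds named here, the only measured step touches the same aromatic carbon and stayed within the scatter; no measured pair exchanges the tert-butyl for a ring system, so no direction can be drawn. Compound 3 is therefore expected near compound 2, at 130 nM with a range from 50 nM to 350 nM. The expected step of a 1.2-fold higher number from compound 2 to compound 3 (0.06 log units; within the scatter) is estimated to stay within the scatter.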

Compound 3, half-maximal effective concentration: 190 nM
The estimate for compound 3 lay 1.5-fold (0.16 log units) below the measured number; measured number inside the range.
By their numbers in this assay, from the lowest: compounds 2, 1 and 3 (each within the scatter of the next).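

In this assay, the earlier pair had only compared open-chain groups on the aromatic carbon para to a methoxy group, whereas compound 3 places a group of 6 heavy atoms with three carbon rings there, giving a 1.7-fold higher number from compound 2 to compound 3 (0.23 log units; within the scatter) from the tert-butyl and a 1.0-fold higher number from compound 1 to compound 3 (0.00 log units; within the scatter) from the smaller open-chain group. This position therefore takes a ring system as well as an open chain, and no order can be read among the three compounds, so neither the added bulk nor the rings show a readable effect on the number. No measurement at hand offers an explanation for this result.

On these data alone, all three groups here contain only carbon and hydrogen, so it remains open how an amine, a nitrile or a morpholine ring would fare on this aromatic carbon. As far as these compounds go, it is equally open whether the same holds with an ethoxy group or a hydroxyl in place of the methoxy group.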